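Swapping the Benzyl Ring: From Dimethoxy to Fluoro

A few compounds are considered here, and "the series" means these few. Any claim that something is new, unique, unknown or untested is made for them only; others in the source may bear on it.

Compound 1, `Nc1cc(N)c2nc(-c3ccccc3)c(Oc3ccc(Cl)c(Cl)c3)nc2c1`, in a functional assay on DU-145 cells (Homo sapiens) for inhibition, read by sulforhodamine B assay, with a stated time of 48 h (on this read-out higher numbers stand for weaker inhibition of growth and lower numbers for stronger inhibition of growth), gives < 100000 nM, which is a limit of the assay and not a number.
Compound 2, `Nc1cc(N)c2nc(-c3ccccc3)c(NCc3ccc(Cl)c(Cl)c3)nc2c1`, gives 33100 nM.
Compound 3, `COc1ccc(CNc2nc3cc(N)cc(N)c3nc2-c2ccccc2)cc1OC`, gives 87100 nM.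

Compound 3 holds the highest of the two numbers; its nearest neighbour is compound 2, and the step between them is a 2.6-fold higher number from compound 2 to compound 3 (0.42 log units; beyond the scatter). For the measured compounds named here, this is the only measured step at the same place, so it is the one that bears on the change that follows.

Compound 4, `Nc1cc(N)c2nc(-c3ccccc3)c(NCc3ccc(F)cc3)nc2c1`, differs from compound 3 in a single respect: 4-fluorophenyl in place of 3,4-dimethoxyphenyl on a saturated chain carbon bound to a nitrogen on an aromatic ring. The measured step shows that exchanging the 3,4-dichlorophenyl of compound 2 for the 3,4-dimethoxyphenyl of compound 3 raised the number modestly. The new ring carries no oxygen and a single fluorine, which brings it closer in kind to the ring of compound 2 than to that of compound 3. A modest fall in the number, roughly reversing part of that measured step, is therefore the expectation here, expressed as a 1.7-fold lower number from compound 3 to compound 4 (0.24 log units; within the scatter). Compound 4 is estimated at 50000 nM, with a likely range from 20000 nM to 120000 nM.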

Compound 4, concentration for total growth inhibition: 3800 nM
Compound 4: the middle estimate sits 13-fold (1.12 log units) above what was measured, and the stated range ends above it.
By their numbers in this assay, from the lowest: compound 4; then compound 2; then compound 3.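

In this assay, the change to 4-fluorophenyl gives a 23-fold lower number from compound 3 to compound 4 (1.36 log units; beyond the scatter), which shows that this ring on the saturated chain carbon can shift the number much further than the earlier swap between two ring types suggested. Set against the 3,4-dichlorophenyl ring, the same group gives an 8.7-fold lower number from compound 2 to compound 4 (0.94 log units; beyond the scatter), so the lower number does not simply reflect the loss of the 3,4-dimethoxyphenyl ring: among these three compounds, both of the larger-named rings, 3,4-dichlorophenyl and 3,4-dimethoxyphenyl, give higher numbers than 4-fluorophenyl. The step from compound 1 to compound 4 cannot be read, because compound 1 gives only a limit: the limit of < 100000 nM in this assay, at which 1 of the 4 values shown sits.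

The compounds shown do not separate the effect of having fluorine on the ring from the effect of having a single group rather than two, and a plain phenyl or a 4-chlorophenyl ring at this position would help to tell these apart. Going by these compounds, it also remains open whether the low number of compound 4 would hold with a longer chain between the ring and the nitrogen.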